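The source may report more compounds than this note shows. Statements on the series, on what has been measured and on what is new or still open speak of the compounds shown alone.

Compound 3 `COc1ccc(F)cc1CNCCCNc1ccnc2cc(Oc3cccc(N(C)C)c3)ccc12` gives 3300 nM in an ADME assay on HepG2 cells (Homo sapiens) for cytotoxicity, read by luminescence, CellTiter-Glo and ATP content, with a stated time of 72 h (on this read-out lower numbers stand for an effect already at smaller amounts and higher numbers for an effect only at larger amounts of compound), the highest of the three numbers recorded there. Compound 1 `COc1ccc(-c2ccc3c(NCCCNCc4cccc(OC)c4O)ccnc3c2)cc1` gives 1600 nM, and compound 2 `COc1cccc(CNCCCNc2ccnc3cc(-c4ccc(C(C)(C)C)cc4)ccc23)c1O` gives 690 nM; compound 3 thus stands above both, by a margin beyond the scatter in each case. Compound 4 `COc1cccc(CNCCCNc2ccnc3cc(Oc4cccc(N(C)C)c4)ccc23)c1O` differs from compound 3 by 2-hydroxy-3-methoxyphenyl in place of 5-fluoro-2-methoxyphenyl on a saturated chain carbon bound to an amine nitrogen. Within the data shown here, the only step measured between close neighbours, a 2.3-fold lower number from compound 1 to compound 2 (0.37 log units; beyond the scatter), concerns another place on the shared core and so does not bear on this change. Among the measured compounds shown here, no measured pair isolates the swap at the saturated chain carbon bound to the amine nitrogen; what can be said is that compound 1 and compound 2, which both carry the 2-hydroxy-3-methoxybenzyl group, return numbers lower than that of compound 3, while also differing from it elsewhere. On that thin basis, compound 4 is expected to show a 1.3-fold lower number from compound 3 to compound 4 (0.12 log units; within the scatter), a modest lowering at most and plausibly none beyond the scatter. Compound 4 is therefore estimated at 2500 nM in this assay, with a range from 1000 nM to 6000 nM.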

Compound 4, half-maximal effective concentration: 7300 nM
Estimate against measurement, compound 4: 2.9-fold (0.47 log units) below; the measured number lies above the stated range.
By their numbers in this assay, from the lowest: compound 2; then compound 1; then compound 3; then compound 4.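

In this assay, the position on a saturated chain carbon bound to an amine nitrogen now has a direct comparison: 2-hydroxy-3-methoxyphenyl in place of 5-fluoro-2-methoxyphenyl gives a 2.2-fold higher number from compound 3 to compound 4 (0.34 log units; beyond the scatter), a modest move upward and the opposite of what compound 1 and compound 2 had hinted at. With the 2-hydroxy-3-methoxybenzyl group held constant, the group on the aromatic carbon also proves to matter, since 3-(dimethylamino)phenoxy in place of 4-(tert-butyl)phenyl gives an 11-fold higher number from compound 2 to compound 4 (1.02 log units; beyond the scatter), a large step, and 3-(dimethylamino)phenoxy in place of 4-methoxyphenyl gives a 4.6-fold higher number from compound 1 to compound 4 (0.66 log units; beyond the scatter), a modest one. The lower numbers of compound 1 and compound 2 therefore go with their groups on the aromatic carbon, not with the benzyl group they share with compound 4.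

Nothing available explains why any of these steps takes the direction or size it does. As far as these compounds go, it also remains open whether the swap at the chain carbon would move the number the same way with 4-(tert-butyl)phenyl on the aromatic carbon, and what a longer chain between the two amine nitrogens or a carboxylic acid on the benzyl ring would do.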